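The source may hold more compounds than are shown below. What is called first, only, known or untested is meant among the compounds shown, and "the series" means these compounds.

Measured compounds in a functional assay on A549 cells (Homo sapiens) for inhibition, read by MTT assay and WST assay, with a stated time of 72 h, tested at 10 uM; a lower number here means less inhibition of growth, a higher number more inhibition of growth at the concentration tested:
compound 1, `O=C(Nc1ccc(Cl)cc1)Nc1ccc(Oc2ccc(-c3nccs3)cc2)cc1`, 17.7%
compound 2, `O=C(Nc1ccc(Oc2ccc(-c3nccs3)cc2)cc1)Nc1ccc(Cl)c([N+](=O)[O-])c1`, 77.1%
compound 3, `O=C(Nc1ccc(Oc2ccc(-c3ncc[nH]3)cc2)cc1)Nc1ccc(Cl)c([N+](=O)[O-])c1`, 12.4%

Compound 3 stands lowest of the three numbers in this assay; compound 1 lies nearest to it, within the scatter, while compound 2 lies furthest above it, beyond the scatter. Compound 4, `O=C(Nc1ccc(Oc2ccc(-c3ncc[nH]3)cc2)cc1)Nc1cc(Br)cc(C(F)(F)F)c1`, is not yet measured. It differs from compound 3 in one place: 3-bromo-5-(trifluoromethyl)phenyl in place of 4-chloro-3-nitrophenyl on an amide-type nitrogen.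

For the measured compounds named here, no measured step covers this exchange directly. The step of a number 59.4 percentage points higher from compound 1 to compound 2 (beyond the scatter) shows what adding a nitro group to this aryl ring did in the thiazole series, and the step of a number 64.7 percentage points lower from compound 2 to compound 3 (beyond the scatter) shows the large drop when the imidazole replaced the thiazole. Compound 4 keeps the imidazole of compound 3 but gives up the nitro group that accompanied the one large rise; on that basis no rise is expected, and a step of a number 0.4 percentage points lower from compound 3 to compound 4 (within the scatter), within the scatter, is the expectation in this assay. Compound 4 is therefore estimated at 12%, with a range from 0% to 35%.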

Compound 4, percent growth inhibition at one concentration: 44.1%
The estimate for compound 4 lay 32.1 percentage points below the measured number; measured number outside the range, above it.
By their numbers in this assay, from the lowest: compounds 3 and 1 (each within the scatter of the next); then compound 4; then compound 2.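

In this assay, the aryl group on the amide-type nitrogen proves to matter even with the imidazole in place: 3-bromo-5-(trifluoromethyl)phenyl in place of 4-chloro-3-nitrophenyl gives a number 31.7 percentage points higher from compound 3 to compound 4 (beyond the scatter), a large step. The earlier steps shown here showed a change on this aryl ring only with the thiazole, where adding a nitro group accompanied a rise; here, a ring with no nitro group and no hydrogen-bond acceptors carries the higher number, so a nitro group is not needed for a rise at this place. No measurement available here explains this rise. The compounds shown leave open whether the bromine or the trifluoromethyl group accounts for the step, and whether the same exchange would raise the number with the thiazole. They also leave open how an aryl ring bearing an amine or a carboxylic acid would behave on this nitrogen.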